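Methoxy to amino on the carbonyl carbon

This account rests on a few compounds, and the source may have more. Where it says the series, first, only, none or still open, it means among the compounds named here.

compound 1 `CNC(=O)/C=C/c1ccncc1-c1ccc2ccccc2c1` gives 8680 nM
compound 2 `CCOC(=O)/C=C/c1ccncc1-c1ccc2ccccc2c1` gives 8090 nM
compound 3 `COC(=O)/C=C/c1ccncc1-c1ccc2ccccc2c1` gives 4710 nM

All three values come from a functional assay on MDA-MB-231 cells (Homo sapiens) for inhibition, read by sulforhodamine B assay, with a stated time of 72 h; a higher number here means a weaker inhibitor of growth, a lower number a stronger inhibitor of growth. The compounds share one core and differ only in the group on the carbonyl carbon. Compound 3 at 4710 nM cannot be separated from the other two. The nearest gap is a 1.7-fold lower number from compound 2 to compound 3 (0.23 log units; within the scatter) and the furthest is a 1.8-fold lower number from compound 1 to compound 3 (0.27 log units; within the scatter), and both lie within the scatter.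

Compound 4 `NC(=O)/C=C/c1ccncc1-c1ccc2ccccc2c1` has not been measured yet. The change is amino in place of methoxy on a carbonyl carbon, which puts amino in place of methoxy on a carbonyl carbon. Within the data shown here, no measured compound carries this amino group. The closest evidence is the exchange of methylamino and methoxy, seen as a 1.8-fold lower number from compound 1 to compound 3 (0.27 log units; within the scatter), which runs opposite to the present change and stays within the scatter. The exchange of methylamino for ethoxy, a 1.1-fold lower number from compound 1 to compound 2 (0.03 log units; within the scatter), also stays within the scatter. On this evidence, no step beyond the scatter is expected in this assay, though a drift towards the number of compound 1 at 8680 nM is plausible. The expected step is a 1.6-fold higher number from compound 3 to compound 4 (0.20 log units; within the scatter). For compound 4 the estimated value is 7500 nM, with an expected range of 3500 nM to 16000 nM.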

Compound 4, concentration for 50% growth inhibition: > 10000 nM
Compound 4 was reported as a limit; the forecaster's own chance of this, stated with the estimate: 5%; middle value at least 1.3-fold (0.12 log units) from the limit.
By their numbers in this assay, from the lowest: compounds 3, 2 and 1 (each within the scatter of the next). At a limit, above all of these: compound 4.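

In this assay, compound 4 is reported only as a limit, > 10000 nM. Among these compounds, on this carbonyl carbon, amino in place of methoxy gives the only step that is beyond the scatter, an at least 2.1-fold higher number from compound 3 to compound 4 (0.32 log units; beyond the scatter), whereas the exchanges among methylamino, ethoxy and methoxy all stayed within it, so the group on this carbon can shift the number in this assay by more than the scatter, at least for this one pair. The other two steps, an at least 1.2-fold higher number from compound 2 to compound 4 (0.09 log units; that floor lies within the scatter) and an at least 1.1-fold higher number from compound 1 to compound 4 (0.06 log units; that floor lies within the scatter), are floors only, so neither fixes a size for amino in place of ethoxy or for hydrogen in place of methyl on the amide-type nitrogen: the limit of > 10000 nM in this assay, at which 1 of the 4 values shown sits.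

On these data alone, the true size of all three steps stays open, and with it whether amino really separates from methylamino or ethoxy in this assay. Also open, as far as these compounds go, is how a carboxylic acid, a dimethylamino group or a longer alkoxy chain on this carbonyl carbon would read in this assay, and whether any group here gives a number clearly lower than that of the methoxy member.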